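The compounds below may be only part of what the source reports. "The series", "measured", "known", "first", "only" and "open" are said of these compounds alone.

Working notes on the dithiocarbamate chalcone series.

Two compounds have been run in a functional assay on ECa-109 cells for inhibition, with ECa-109 cell line (Homo sapiens) as the target, read by MTT assay, with a stated time of 72 h; on this read-out higher numbers stand for weaker inhibition and lower numbers for stronger inhibition. Compound 1 `COc1cc(/C=C/C(=O)c2ccc(OCCCSC(=S)N3CCCC3)cc2)cc(OC)c1OC` gives 11100 nM. Compound 2 `O=C(/C=C/c1ccc(Cl)cc1)c1ccc(OCCSC(=S)N2CCOCC2)cc1` gives 15400 nM. In this assay the two numbers lie within the usual scatter of each other, so no order between compound 1 and compound 2 can be claimed from these two measurements alone; both sit at the weak end of what this read-out resolves.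

Compound 3 `COc1cc(/C=C/C(=O)c2ccc(OCCSC(=S)N3CCCCC3)cc2)cc(OC)c1OC` has not yet been measured. It differs from compound 1 in one place: a group of 9 heavy atoms (6 carbon, 1 nitrogen, 2 sulfur; one six-membered non-aromatic ring with 1 hetero atom) in place of a group of 9 heavy atoms (6 carbon, 1 nitrogen, 2 sulfur; one five-membered non-aromatic ring with 1 hetero atom), on a saturated chain carbon, two bonds along the chain from an oxygen on an aromatic ring. The two structures hold the same atoms joined differently, so the swap changes the shape of the terminal amine and the length of the linker but nothing else in the molecule.

Within the data shown here, there is no measured pair in this set that isolates such a change, so the size of the step has no precedent here. Among the measured compounds shown here, with only two weakly inhibiting compounds available, the plain expectation is a step of no more than the scatter, in either direction. Compound 3 is accordingly expected to give about 10000 nM, with a range from 4000 nM to 25000 nM. That estimate amounts to an expected step of a 1.1-fold lower number from compound 1 to compound 3 (0.05 log units; within the scatter), which is expected to stay within the scatter.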

Compound 3, half-maximal inhibitory concentration: 38900 nM
Compound 3: middle estimate off by 3.9-fold (0.59 log units), on the low side, outside the stated range (above it).
By their numbers in this assay, from the lowest: compounds 1 and 2 (each within the scatter of the next); then compound 3.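

In this assay, among these compounds, replacing the group bearing one five-membered non-aromatic ring with 1 hetero atom by the group bearing one six-membered non-aromatic ring with 1 hetero atom gives a 3.5-fold higher number from compound 1 to compound 3 (0.54 log units; beyond the scatter), which is a modest loss of inhibition and the first step to lie beyond the scatter. This place on the saturated chain carbon, two bonds along the chain from an oxygen on an aromatic ring, is therefore not silent, even though the swap leaves the atom count of the group unchanged and the rest of compound 1 untouched. Nothing on hand bears on the origin of this step.

The terminal ring and the linker length change together in this one step, so the compounds shown do not separate the contribution of either, and the step rests on a single pair. On these data alone, whether a longer chain, a piperazine ring or a dimethylamino group at this place would give a lower number than the five-membered ring of compound 1 remains open, as does whether the same step would recur on a different core.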